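Swapping the Aryl Group on the Sulfonyl Sulfur

A few compounds are considered here, and "the series" means these few. Any claim that something is new, unique, unknown or untested is made for them only; others in the source may bear on it.

Of the compounds shown here, three sharing one core have been tested in an ADME assay on HEK293 cells (Homo sapiens) for cytotoxicity, read by resazurin assay, with a stated time of 48 h; on this read-out lower numbers stand for higher toxicity in this test and higher numbers for lower toxicity in this test. Compound 1 `Cc1cccc(S(=O)(=O)Nc2ccc3oc(-c4ccccc4)nc3c2)c1` gives 69000 nM, compound 2 `C=Cc1ccc(S(=O)(=O)Nc2ccc3oc(-c4ccccc4)nc3c2)cc1` gives 53000 nM, and compound 3 `O=S(=O)(Nc1ccc2oc(-c3ccccc3)nc2c1)c1cccc(F)c1` gives 68000 nM. On the bare numbers, compound 3 holds the second highest of the three, with compound 1 nearest and compound 2 furthest, yet every gap is within the scatter: a 1.0-fold lower number from compound 1 to compound 3 (0.01 log units; within the scatter) and a 1.3-fold higher number from compound 2 to compound 3 (0.11 log units; within the scatter).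

Compound 4 `COc1ccc(S(=O)(=O)Nc2ccc3oc(-c4ccccc4)nc3c2)cc1` has not yet been measured. It differs from compound 3 in one place: 4-methoxyphenyl in place of 3-fluorophenyl on a sulfonyl sulfur.

Among the measured compounds shown here, the steps that bear on this change are those that also swap the group on the sulfonyl sulfur. The step of a 1.3-fold lower number from compound 1 to compound 2 (0.11 log units; within the scatter) and the step of a 1.3-fold higher number from compound 2 to compound 3 (0.11 log units; within the scatter) both stayed within the scatter, as did the smaller change a 1.0-fold lower number from compound 1 to compound 3 (0.01 log units; within the scatter). Nothing in these numbers points to a move beyond the scatter when this aryl group is varied, so no step beyond the scatter is expected in this assay for compound 4, and the estimated step is a 1.0-fold lower number from compound 3 to compound 4 (0.02 log units; within the scatter). Compound 4 is therefore expected to give about 65000 nM, with a range from 32000 nM to 130000 nM.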

Compound 4, half-maximal cytotoxic concentration: 91000 nM
The estimate for compound 4 lay 1.4-fold (0.15 log units) below the measured number; the range from low to high includes it.
By their numbers in this assay, from the lowest: compounds 2, 3, 1 and 4 (each within the scatter of the next).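

Unlike 3-fluorophenyl, which counts no hydrogen-bond acceptor, 4-methoxyphenyl counts one, yet in this assay this swap on the sulfonyl sulfur stays within the scatter (a 1.3-fold higher number from compound 3 to compound 4 (0.13 log units; within the scatter)). The same holds when 4-methoxyphenyl replaces 3-methylphenyl (a 1.3-fold higher number from compound 1 to compound 4 (0.12 log units; within the scatter)), and even the widest step among these four compounds, methoxy in place of vinyl, does not leave the scatter (a 1.7-fold higher number from compound 2 to compound 4 (0.23 log units; within the scatter)). So all four aryl groups at this position give numbers that cannot be told apart in this test, and nothing measured here offers an explanation for that.

On these data alone, whether this holds for an aryl group carrying an amine or a carboxylic acid, or for a longer chain on the sulfonyl sulfur, remains open. As far as these compounds go, how changes elsewhere on the shared core would affect the number also remains open.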